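The source may report more compounds than this note shows. Statements on the series, on what has been measured and on what is new or still open speak of the compounds shown alone.

Working notes on the aryl-hydrazone urea series. Three compounds have numbers in a functional assay on MKN-45 cells (Homo sapiens) for cytotoxicity, read by MTT assay, with a stated time of 72 h; on this read-out lower numbers stand for stronger inhibition and higher numbers for weaker inhibition. Compound 1 `COc1ccc(OC)c(/C=N/NC(=O)Nc2ccc(Oc3ccnc(-c4nncn4CCN(C)C)c3)c(F)c2)c1` gives 1510 nM. Compound 2 `CN(C)CCn1cnnc1-c1cc(Oc2ccc(NC(=O)N/N=C/c3ccc(Cl)cc3)cc2F)ccn1` gives 570 nM. Compound 3 `CN(C)CCn1cnnc1-c1cc(Oc2ccc(NC(=O)N/N=C/c3ccc(F)cc3)cc2F)ccn1` gives 1030 nM. Compound 3 sits between the other two, but the steps of a 1.5-fold lower number from compound 1 to compound 3 (0.17 log units; within the scatter) and a 1.8-fold higher number from compound 2 to compound 3 (0.26 log units; within the scatter) are both within the scatter, so compound 3 is not separated from either of them on these numbers. For the measured compounds named here, the only step beyond the scatter is a 2.6-fold lower number from compound 1 to compound 2 (0.42 log units; beyond the scatter).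

Compound 4 `COc1ccc(/C=N/NC(=O)Nc2ccc(Oc3ccnc(-c4nncn4CCN(C)C)c3)c(F)c2)c(OC)c1OC` is the next member to be measured in this assay. It differs from compound 3 in one place: 2,3,4-trimethoxyphenyl in place of 4-fluorophenyl on a carbon with a double bond to nitrogen.

Going by the values given here, the steps that bear on this change are those at the same carbon with a double bond to nitrogen. The step of a 1.5-fold lower number from compound 1 to compound 3 (0.17 log units; within the scatter) shows that going from a methoxy-bearing phenyl to 4-fluorophenyl stayed within the scatter, while a 2.6-fold lower number from compound 1 to compound 2 (0.42 log units; beyond the scatter) went beyond it. Among the compounds with values here, compound 4 reverses the direction of those steps, but with a trimethoxy pattern that no measured compound carries, so any expectation is loose. A higher number than compound 3, of the order of the 1>3 step reversed, is expected rather than a step beyond the scatter in either direction.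

Compound 4 is therefore estimated at 1600 nM, with a range of 700 nM to 3600 nM, an expected step of a 1.6-fold higher number from compound 3 to compound 4 (0.19 log units; within the scatter).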

Compound 4, half-maximal inhibitory concentration: 2020 nM
Beside the measured number, compound 4's estimate is 1.3-fold (0.10 log units) below it, and the stated range covers the measured number.
By their numbers in this assay, from the lowest: compounds 2, 3, 1 and 4 (each within the scatter of the next, the first and the last beyond it).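

In this assay, the 2,3,4-trimethoxyphenyl group on the carbon with a double bond to nitrogen gives the second step beyond the scatter at this position (a 3.5-fold higher number from compound 2 to compound 4 (0.55 log units; beyond the scatter)), so compound 2 now stands apart from both methoxy-bearing members, compound 1 and compound 4. The other two steps stay within the scatter (a 2.0-fold higher number from compound 3 to compound 4 (0.29 log units; within the scatter); a 1.3-fold higher number from compound 1 to compound 4 (0.13 log units; within the scatter)): going to 12 heavy atoms and 3 hydrogen-bond acceptors from the 7 heavy atoms and 0 acceptors of 4-fluorophenyl does not separate compound 4 from compound 3, and the two methoxy patterns are not told apart from each other. Nothing at hand accounts for any of these steps.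

The four groups shown are all phenyl rings carrying halogen or methoxy, so it remains open how a pyridyl ring, or a phenyl ring carrying an amine or a carboxylic acid, would read at this carbon. Also open, going by these compounds, is whether bromo in place of chloro would hold the separation seen for compound 2, since chloro and fluoro themselves are not separated here.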